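The source may report more compounds than this note shows. Statements on the series, on what has been measured and on what is new or still open speak of the compounds shown alone.

Compound 1 `O=CN1N=C(c2ccc(F)cc2)CC1c1cn(-c2ccccc2)nc1-c1ccc(Cl)c(Cl)c1`: 60.9%
Compound 2 `CC(=O)N1N=C(c2ccc(C)cc2)CC1c1cn(-c2ccccc2)nc1-c1ccc(Cl)c(Cl)c1`: 70.3%

Of the compounds shown here, two have been tested in a functional assay on the whole organism (strain Wistar) for inhibition, with Rattus norvegicus as the target, read by paw edema, with stated times of 30 min and 120 min, at a dose of 50 mg/kg by the oral route; a higher number here means more inhibition at the dose given (going by the name of the read-out), a lower number less inhibition. Compound 1 gives 60.9%, and compound 2 gives 70.3%. For the measured compounds named here, of the two numbers, the one for compound 2 is the larger, yet its gap to compound 1 lies within the usual scatter, so the two compounds cannot be told apart on this evidence. Going by the values given here, no single-point step between them is on record, since compound 1 and compound 2 differ in more than one place.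

Compound 3 `Cc1ccc(C2=NN(C=O)C(c3cn(-c4ccccc4)nc3-c3ccc(Cl)c(Cl)c3)C2)cc1` has not yet been measured in this assay. It is derived from compound 2 by a change (hydrogen in place of methyl on a carbonyl carbon). Among the compounds with values here, nothing among the measured compounds isolates this change on its own, so its effect is open. Compound 1 carries the formyl group and sits within the scatter of compound 2, which suggests that the change is unlikely to be large. The step of a number 6.3 percentage points lower from compound 2 to compound 3 (within the scatter) is therefore expected to stay within the scatter, with no direction favoured. On this basis compound 3 is expected to give about 64% in this assay, with a range from 50% to 78%.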

Compound 3, a percentage reported as inhibition, in the whole organism at one dose (the size of the read-out at that dose, not a potency): 60.9%
Compound 3: the middle estimate sits 3.1 percentage points above what was measured; low and high end bracket the measured number.
By their numbers in this assay, from the lowest: compounds 1, 3 and 2 (each within the scatter of the next).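

In this assay, the pair of compound 2 and compound 3 isolates the change from acetyl to formyl and gives a number 9.4 percentage points lower from compound 2 to compound 3 (within the scatter), so hydrogen in place of methyl on this carbonyl carbon, whose other neighbour is an amide-type nitrogen in a ring, cannot be told apart from no change at this dose. The pair of compound 1 and compound 3 isolates a second place and gives no change at the digits printed from compound 1 to compound 3 (within the scatter), so methyl in place of fluoro on an aromatic carbon also cannot be told apart from no change, which the first two compounds, differing in more than one place, could not show. Nothing measured here speaks to the reason for either result.

From the compounds shown here alone, with one dose, the read-out gives the size of the inhibition at that dose and not a potency, so differences between the three compounds at other doses remain open. Going by these compounds, it also remains open whether a longer chain such as propionyl or an amine-bearing group such as aminoacetyl on this carbonyl carbon, or a methoxy group on the aromatic carbon, would move the read-out beyond the scatter.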